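The source may hold more compounds than are shown below. What is called first, only, known or untested is meant among the compounds shown, and "the series" means these compounds.

Measured so far:
compound 1 `COc1ccc(C(=O)/C=C/c2ccc(-n3ccnc3)cc2)c2c1C=CC(C)(C)O2`: > 10000 nM
compound 2 `COc1ccc(C(=O)/C=C/c2ccsc2)c2c1C=CC(C)(C)O2`: > 10000 nM

In a functional assay on SW-620 cells (Homo sapiens) for antiproliferative activity, read by MTT assay, with a stated time of 24 h (on this read-out lower numbers stand for stronger inhibition and higher numbers for weaker inhibition), compound 2 gives > 10000 nM, a limit of the assay and not a number. Compound 1 likewise returns only a limit, > 10000 nM. Both values shown stand at the limit of > 10000 nM in this assay, at which 2 of the 2 values shown sit, so compound 2 cannot be placed against compound 1 on the numbers. Compound 3 `COc1ccc(C(=O)/C=C/c2ccc(O)cc2)c2c1C=CC(C)(C)O2` carries 4-hydroxyphenyl in place of thiophen-3-yl on a double-bonded chain carbon bound to a double-bonded chain carbon. Because compound 2 shows only > 10000 nM, no step beyond the scatter is expected for compound 3. Compound 3 is expected near 15000 nM, between 3000 nM and 60000 nM. The step expected is a step that the limit leaves unreadable from compound 2 to compound 3.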

Compound 3, half-maximal inhibitory concentration: > 10000 nM
Compound 3: no number, only a limit; the forecaster's own chance of this, stated with the estimate: 70%; the middle value is on the limit's open side.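

No new step can be read for compound 3 against compound 2 or compound 1 in this assay, where all three give only a limit: the limit of > 10000 nM in this assay, at which 3 of the 3 values shown sit.
On these data alone, how these three compounds rank against one another remains open, as does which group on the shared core would give a measurable value.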